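Loss of the chloro group: compound 3 to compound 4

The compounds below may be only part of what the source reports. "The series", "measured", "known", "first", "only" and "open" are said of these compounds alone.

Measured compounds:
compound 1, `COc1cc(Nc2nc(Cl)cc3c(C(C)C)n[nH]c23)cc(OC)c1OC`, gives 550 nM in an assay on Flp-In-CHO cells for binding affinity to adenosine receptor A3 (Homo sapiens), using Schild analysis; on this read-out lower numbers stand for tighter binding and higher numbers for weaker binding;
compound 2, `N#Cc1cc2c(-c3ccccc3)n[nH]c2c(Nc2ccccc2)n1`, gives 17 nM in this assay;
compound 3, `COc1cc(Nc2nc(Cl)cc3c(-c4ccccc4)n[nH]c23)cc(OC)c1OC`, gives 89.1 nM in this assay.

In this assay compound 3 stands second highest of the three numbers, with compound 2 lower and compound 1 higher. Going by the values given here, the only single-place step recorded, a 6.2-fold lower number from compound 1 to compound 3 (0.79 log units; beyond the scatter), concerns a different position and says nothing about the ring carbon in question. Compound 4, `COc1cc(Nc2nccc3c(-c4ccccc4)n[nH]c23)cc(OC)c1OC`, differs from compound 3 by hydrogen in place of chloro on an aromatic carbon. Among the compounds with values here, no measured pair isolates this change; compound 2 carries a nitrile at that place but also differs elsewhere, so its number cannot be read as a step. With nothing to scale it, no step beyond the scatter is expected, and compound 4 is estimated at 130 nM (range 45 nM to 400 nM), an expected 1.5-fold higher number from compound 3 to compound 4 (0.16 log units; within the scatter).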

Compound 4, dissociation constant: 251 nM
Beside the measured number, compound 4's estimate is 1.9-fold (0.29 log units) below it, within the range that was stated.
By their numbers in this assay, from the lowest: compound 2; then compound 3; then compound 4; then compound 1.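

In this assay, going by these compounds alone, hydrogen in place of chloro, on the aromatic carbon next to the ring nitrogen, gives a 2.8-fold higher number from compound 3 to compound 4 (0.45 log units; beyond the scatter) and is the first single-place reading at this carbon. The step lies beyond the scatter, so the number here does depend on what this carbon carries, with chloro going with the lower number. Nothing at hand accounts for the step. As far as these compounds go, whether fluoro, methyl or an amine at this carbon would match chloro stays open, as does whether the step holds with isopropyl in place of phenyl.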